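Chain Length and Ring Swap in a Serotonin Receptor Series

This account rests on a few compounds, and the source may have more. Where it says the series, first, only, none or still open, it means among the compounds named here.

Of the compounds shown here, three sharing one core have been measured in an assay on HEK293 cells for displacement of a labelled ligand from 5-hydroxytryptamine receptor 4 (Homo sapiens), read by scintillation counting; on this read-out higher numbers stand for weaker inhibition and lower numbers for stronger inhibition. Compound 1 `COc1cc(N)c(Cl)cc1C(=O)NC1CCN(CCCCCN2CCCCC2)CC1` gives 10 nM in this assay. Compound 2 `COc1cc(N)c(Cl)cc1C(=O)NC1CCN(CCCCCCCCN2CCCCC2)CC1` gives 3.16 nM in this assay, and compound 3 `COc1cc(N)c(Cl)cc1C(=O)NC1CCN(CCCCCN2CCN(S(C)(=O)=O)CC2)CC1` gives 39.8 nM in this assay. The cores of compound 1 and compound 2 differ as described by 3-(piperidin-1-yl)propyl in place of piperidin-1-yl on a saturated chain carbon, five bonds along the chain from an amine nitrogen in a ring, and that step reads a 3.2-fold lower number from compound 1 to compound 2 (0.50 log units; beyond the scatter). Compound 2 stands lowest of the three, with a 13-fold higher number from compound 2 to compound 3 (1.10 log units; beyond the scatter) as the largest gap.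

The change from compound 1 to compound 3 is 4-(methylsulfonyl)piperazin-1-yl in place of piperidin-1-yl on a saturated chain carbon, five bonds along the chain from an amine nitrogen in a ring, and it made a step of a 4.0-fold higher number from compound 1 to compound 3 (0.60 log units; beyond the scatter). Compound 4 `COc1cc(N)c(Cl)cc1C(=O)NC1CCN(CCCCCCCCN2CCN(S(C)(=O)=O)CC2)CC1` has not yet been measured in this assay. It differs from compound 2 by 4-(methylsulfonyl)piperazin-1-yl in place of piperidin-1-yl on a saturated chain carbon, eight bonds along the chain from an amine nitrogen in a ring. Among the measured compounds shown here, this is the same kind of change as the one from compound 1 to compound 3, but the place differs: in the earlier pair the group sits five bonds along the chain from an amine nitrogen in a ring, whereas in the new pair it sits eight bonds along the chain from an amine nitrogen in a ring.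

Resting on the single earlier example of this kind of change, namely a 4.0-fold higher number from compound 1 to compound 3 (0.60 log units; beyond the scatter), the expected step from compound 2 to compound 4 is estimated at a 4.0-fold higher number from compound 2 to compound 4 (0.60 log units; beyond the scatter), beside the earlier one. For the measured compounds named here, compound 4 is therefore expected to give about 12.6 nM in this assay, with a likely range from 4 nM to 40 nM, because the longer chain in compound 2 3.16 nM offers no second example of the same swap to narrow the estimate.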

Compound 4, inhibition constant: 15.9 nM
The estimate for compound 4 lay 1.3-fold (0.10 log units) below the measured number; the range from low to high includes it.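

In this assay, placing 4-(methylsulfonyl)piperazin-1-yl where piperidin-1-yl stood, eight bonds along the chain from an amine nitrogen in a ring, gave a 5.0-fold higher number from compound 2 to compound 4 (0.70 log units; beyond the scatter). Among the compounds shown here, the swap therefore carried from the shorter-chain core to the longer-chain core with its direction kept and no size difference that can be told apart from the scatter: the same change on two cores in this assay, a 4.0-fold higher number (0.60 log units; beyond the scatter) from compound 1 to compound 3 and a 5.0-fold higher number (0.70 log units; beyond the scatter) from compound 2 to compound 4, 1.3-fold (0.10 log units) apart, within the scatter of two such steps This agreement rests on only two pairs, so it shows that the swap behaved alike at these two chain lengths, but it does not establish a constant step for other cores and gives no reason for the step.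

The compounds shown leave open whether the same step would appear with a shorter chain or a still longer chain between the two amine rings. They also leave open how other replacements for piperidin-1-yl, such as morpholin-4-yl or 4-acetylpiperazin-1-yl, would compare with 4-(methylsulfonyl)piperazin-1-yl on either core.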